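Swapping a Methyl for a Phenyl on a Fused Amine

The source may report more compounds than this note shows. Statements on the series, on what has been measured and on what is new or still open speak of the compounds shown alone.

Compound 1 `COc1ccc(-c2cnc3cc4c(cc3n2)C2CNCC4C2)cc1`: 26 nM
Compound 2 `c1c[nH]c(-c2ccc3c(c2)C2CNCC3C2)c1`: 68 nM
Compound 3 `CCc1nc2cc3c(cc2o1)C1CNCC3C1`: 12 nM

In an assay for binding affinity to Neuronal acetylcholine receptor; alpha4/beta2 (Rattus norvegicus) (on this read-out higher numbers stand for weaker inhibition and lower numbers for stronger inhibition), compound 3 stands lowest of the three values. Its nearest neighbour is compound 1, whose number is higher by a gap beyond the usual scatter, and the furthest is compound 2, higher still. Compound 3 is therefore the strongest binder among the three measured compounds.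

Compound 4 `c1ccc(Cc2nc3cc4c(cc3o2)C2CNCC4C2)cc1` is built from compound 3 by one change: phenyl in place of methyl on a saturated chain carbon bound to an aromatic carbon. Among the compounds with values here, no pair of measured compounds shows this same change, so the expectation for compound 4 rests only on the general picture. Compound 1 carries a larger aromatic group on its core and in this assay still gives 26 nM, which suggests that bulk of this kind is tolerated, though at some cost. Compound 4 is expected to give 40 nM, with a range from 10 nM to 160 nM. The expected step of a 3.3-fold higher number from compound 3 to compound 4 (0.52 log units; beyond the scatter) points toward weaker binding, of a size that may just pass beyond the scatter.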

Compound 4, inhibition constant: 100 nM
Compound 4: the middle estimate sits 2.5-fold (0.40 log units) below what was measured; low and high end bracket the measured number.
By their numbers in this assay, from the lowest: compound 3; then compound 1; then compounds 2 and 4 (each within the scatter of the next).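

In this assay, phenyl in place of methyl on a saturated chain carbon bound to an aromatic carbon gives an 8.3-fold higher number from compound 3 to compound 4 (0.92 log units; beyond the scatter) and so moves binding in the weaker direction. Within the data shown here, this is the first single change measured in this set, and it shows that this position responds to what it carries, although compound 4 still gives a measured value of 100 nM with the larger group in place. No supporting data bear on why the number rises.

This one step cannot separate the effect of adding carbons from that of adding an aromatic ring, a question that a propyl chain or a cyclohexyl ring at the same place could address. It also leaves open how an amine or a hydroxyl on the phenyl ring would shift the value.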